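This account rests on a few compounds, and the source may have more. Where it says the series, first, only, none or still open, it means among the compounds named here.

In a functional assay on brain (Rattus norvegicus, strain Wistar) for inhibition (a lower number here means a stronger inhibitor, a higher number a weaker inhibitor), compound 3 (`CCCCCCCCCCOc1ccc(-c2c(C)[nH]c(=O)n2C2CCCCC2)cc1`) gives 10500 nM, and compound 2 (`CCCCCCCCOc1ccc(-c2c(C)[nH]c(=O)n2C2CCCCC2)cc1`) gives 8500 nM. Among the measured compounds shown here, the only measured chain step, a 1.2-fold higher number from compound 2 to compound 3 (0.09 log units; within the scatter), therefore leaves the two compounds level. Compound 4 (`CCCCCCCCCCCCCCCCCCOc1ccc(-c2c(C)[nH]c(=O)n2C2CCCCC2)cc1`) differs from compound 3 by octyl in place of hydrogen on a saturated chain carbon, ten or more bonds along the chain from an oxygen on an aromatic ring. For the measured compounds named here, this change is far longer than the one measured step, so that step is a weak guide. Compound 4 has the chain of compound 1 (`CCCCCCCCCCCCCCCCCCOc1ccc(-c2c(C)[nH]c(=O)n2C)cc1`), which is reported only as a limit, > 100000 nM. A moderately weaker result is therefore expected, with an estimated 2.4-fold higher number from compound 3 to compound 4 (0.38 log units; beyond the scatter). For compound 4, the expected value in this assay is 25000 nM, with an estimated range of 8000 nM to 90000 nM.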

Compound 4, half-maximal inhibitory concentration: > 100000 nM
Compound 4: no number, only a limit; the forecaster's own chance of this, stated with the estimate: 30%; at least 4.0-fold (0.60 log units) between middle value and limit.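

In this assay, the earlier chain step stayed within the scatter, but the longest chain now shows a clear loss: an at least 9.5-fold higher number from compound 3 to compound 4 (0.97 log units; beyond the scatter), and an at least 11-fold higher number from compound 2 to compound 4 (1.07 log units; beyond the scatter). So chain length at this position does matter among the cyclohexyl compounds, once the octyl group is added. Compound 1 and compound 4 are both reported only as limits, so the step between them cannot be read: the limit of > 100000 nM in this assay, at which 2 of the 4 values shown sit.

Still open, going by these compounds, is how a dodecyl chain would read in this assay, which would help place where the loss sets in. Also open, on these data alone, is whether a chain carrying a carboxylic acid would behave differently.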